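A few compounds are considered here, and "the series" means these few. Any claim that something is new, unique, unknown or untested is made for them only; others in the source may bear on it.

Compound 1 `COc1ccccc1-c1cn(-c2ccc(O)c(C(=O)OCCCc3ccccc3)c2)nn1`: 7%
Compound 2 `COC(=O)c1cc(-n2cc(-c3cccc(O)c3)nn2)ccc1O`: 6%

Of the compounds shown here, two sharing one core have been tested in a functional assay on HCT-116 cells (Homo sapiens) for inhibition, read by MTT assay, with a stated time of 2 days, tested at 10 uM; on this read-out higher numbers stand for more inhibition at the one concentration tested (going by the name of the read-out) and lower numbers for less inhibition. In this assay compound 2 gives 6%, and compound 1 gives 7%. The gap between these two numbers lies within the scatter of repeated measurements, so both compounds show about the same weak inhibition at the concentration tested, and neither can be set apart from the other.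

Compound 3 `COC(=O)c1cc(-n2cc(-c3ccccc3OC)nn2)ccc1O` has not yet been measured. It keeps the methyl ester of compound 2 and differs from compound 2 in one place: 2-methoxyphenyl in place of 3-hydroxyphenyl on an aromatic carbon. The same 2-methoxyphenyl group is found in compound 1, whose value sits within the scatter of compound 2, so nothing seen so far points to a step in this assay beyond the scatter in either direction; the expected step from compound 2 is a number 1 percentage points higher from compound 2 to compound 3 (within the scatter). On that basis compound 3 is expected to give about 7% in this assay, with the estimate ranging from 0% to 18%.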

Compound 3, a percentage reported as inhibition, at one concentration (the size of the read-out at that concentration, not a potency): 8%
Beside the measured number, compound 3's estimate is 1 percentage points below it; the measured number falls inside the stated range.
By their numbers in this assay, from the lowest: compounds 2, 1 and 3 (each within the scatter of the next).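

In this assay, putting 2-methoxyphenyl in place of 3-hydroxyphenyl on the aromatic carbon of the five-membered ring gives a number 2 percentage points higher from compound 2 to compound 3 (within the scatter), so this position can now be read through a single difference, and losing the hydroxyl-bearing ring does not set compound 3 apart from compound 2. With the 2-methoxyphenyl group held fixed, the ester end can also be read on its own: hydrogen in place of phenethyl on a saturated chain carbon bound to an oxygen next to a carbonyl group gives a number 1 percentage points higher from compound 1 to compound 3 (within the scatter), so that large change in the chain also stays within the scatter. No independent measurement is available to explain these results.

All of these compounds show only weak inhibition at the one concentration tested, so these steps say little about how either position would behave in a compound with stronger inhibition. From the compounds shown here alone, it remains open whether an amine on this aromatic carbon, or a carboxylic acid in place of the methyl ester, would give a step beyond the scatter.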